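Aryl sulfonate in place of propanoate on the phenolic oxygen

The compounds below may be only part of what the source reports. "The series", "measured", "known", "first", "only" and "open" are said of these compounds alone.

Cytotoxicity across the series was read in a functional assay on A-375 cells (Homo sapiens) for cytotoxicity, read by MTT assay; a higher number here means a weaker inhibitor, a lower number a stronger inhibitor.

Compound 1 `CCC(=O)Oc1cc(/C=C/C(=O)c2ccc(OC)c3c2OC(C)(C)C=C3)ccc1OC`: 240 nM
Compound 2 `COc1ccc(/C=C/C(=O)c2ccc(OC)c3c2OC(C)(C)C=C3)cc1OC(=O)CCl`: 450 nM
Compound 3 `COc1ccc(/C=C/C(=O)c2ccc(OC)c3c2OC(C)(C)C=C3)cc1OS(=O)(=O)Cc1ccccc1`: > 10000 nM, a limit
Compound 4 `COc1ccc(/C=C/C(=O)c2ccc(OC)c3c2OC(C)(C)C=C3)cc1OS(=O)(=O)c1ccc(C)cc1`: not yet measured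

Compound 1 carries the lowest of the two numbers obtained so far. Compound 2 is close to it, a 1.9-fold higher number from compound 1 to compound 2 (0.27 log units; within the scatter), so no order between the two can be read. Compound 3 yields only a limit of this assay, not a number. Two measured steps already lead to a sulfonate on this oxygen: an at least 41-fold higher number from compound 1 to compound 3 (1.61 log units; beyond the scatter) and an at least 22-fold higher number from compound 2 to compound 3 (1.34 log units; beyond the scatter), both large, with compound 3 sitting at the limit of > 10000 nM in this assay, at which 1 of the 3 values shown sits.

Compound 4 carries (4-methylphenyl)sulfonyl in place of propanoyl on an oxygen on an aromatic ring. Compared with compound 3 the sulfonyl bears an aromatic ring directly rather than a benzyl chain, but both replace a carbonyl-linked ester with a sulfonyl-linked one, and the measured sulfonate step was large. Compound 4 is therefore expected to show a 33-fold higher number from compound 1 to compound 4 (1.52 log units; beyond the scatter), a large rise in this assay, quite possibly again ending at the limit. The estimate for compound 4 in this assay is 8000 nM, within 1500 nM to 30000 nM.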

Compound 4, half-maximal inhibitory concentration: 2400 nM
Beside the measured number, compound 4's estimate is 3.3-fold (0.52 log units) above it, and the stated range covers the measured number.
By their numbers in this assay, from the lowest: compounds 1 and 2 (each within the scatter of the next); then compound 4. At a limit, above all of these: compound 3.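

A sulfonate on this oxygen does not by itself push the number to the limit of this assay: the (4-methylphenyl)sulfonyl ester still gives a measurable value, with a 10-fold higher number from compound 1 to compound 4 (1.00 log units; beyond the scatter) and a 5.3-fold higher number from compound 2 to compound 4 (0.73 log units; beyond the scatter), both modest. The group on the sulfonyl sulfur therefore counts as well, as 4-methylphenyl in place of benzyl gives an at least 4.1-fold lower number from compound 3 to compound 4 (0.61 log units; beyond the scatter). Compound 3 remains a limit and not a number: the limit of > 10000 nM in this assay, at which 1 of the 4 values shown sits.

The compounds shown leave open whether a methylsulfonyl or an unsubstituted phenylsulfonyl ester would fall nearer compound 4 or compound 3. Also open, as far as these compounds go, is whether a carbamate or a longer acyl chain such as hexanoyl on this oxygen would stay within the scatter of compound 1 and compound 2.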